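This account rests on a few compounds, and the source may have more. Where it says the series, first, only, none or still open, it means among the compounds named here.

Measured so far in an in vitro ADME assay on microsomes (Rattus norvegicus) for metabolic stability; a higher number here means that the compound lasts longer, a lower number that the compound disappears faster:
- Compound 1 `Cc1c2c(n3c1CCN(C(=O)[C@H](C)N)CC[C@H](C)Nc1cc-3ccc1C(N)=O)CC(C)(C)CC2=O`: > 0.5 h, a limit of the assay
- Compound 2 `Cc1c2c(n3c1CCN(C(=O)[C@@H](N)C(C)C)C[C@@H](C)[C@H](C)Nc1cc-3ccc1C(N)=O)CC(C)(C)CC2=O`: 0.217 h
- Compound 3 `Cc1c2c(n3c1CCN(C(=O)C1(N)CCCC1)C[C@@H](C)[C@H](C)Nc1cc-3ccc1C(N)=O)CC(C)(C)CC2=O`: 0.0833 h

Compound 2, at 0.217 h, holds the higher of the two exact numbers. The reading for compound 1, > 0.5 h, is a limit and not a number, so it cannot be ranked in the same way.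

Compound 4 `Cc1c2c(n3c1CCN(C(=O)[C@@H](O)C(C)C)C[C@@H](C)[C@H](C)Nc1cc-3ccc1C(N)=O)CC(C)(C)CC2=O` keeps the structure of compound 2 but makes one exchange: hydroxy in place of amino on a saturated chain carbon bound to a carbonyl carbon and a saturated chain carbon. Hydroxy stands in place of amino on a saturated chain carbon bound to a carbonyl carbon and a saturated chain carbon.

Within the data shown here, only one measured step touches this part of the molecule. That step, a 2.6-fold lower number from compound 2 to compound 3 (0.42 log units; beyond the scatter), replaces 1-amino-2-methylpropyl with 1-aminocyclopentyl. It is modest but beyond the scatter, so changes in this group can move the half-life. However, it keeps the amino group, and no measured pair swaps amino for hydroxy, so it gives a rough size and no direction.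

The expected change in this assay is therefore small, and the estimate is a 1.1-fold lower number from compound 2 to compound 4 (0.04 log units; within the scatter), with a real move of similar size possible either way. The estimated half-life of compound 4 is 0.2 h, with an expected range from 0.08 h to 0.5 h.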

Compound 4, half-life: 0.317 h
The estimate for compound 4 lay 1.6-fold (0.20 log units) below the measured number, and the stated range covers the measured number.
By their numbers in this assay, from the lowest: compound 3; then compounds 2 and 4 (each within the scatter of the next). At a limit, above all of these: compound 1.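

In this assay, the only direct test of this exchange on a saturated chain carbon bound to a carbonyl carbon and a saturated chain carbon gives a 1.5-fold higher number from compound 2 to compound 4 (0.16 log units; within the scatter), so the half-life does not depend measurably on having amino rather than hydroxy at this place. The wider step, a 3.8-fold higher number from compound 3 to compound 4 (0.58 log units; beyond the scatter), is beyond the scatter and changes the whole group on the carbonyl carbon, 1-hydroxy-2-methylpropyl in place of 1-aminocyclopentyl; with compound 2 and compound 4 within the scatter of each other, the short half-life of compound 3 goes with its 1-aminocyclopentyl group and not with the amino group alone. Both numbers in the step from compound 2 to compound 4 are exact readings, and only one value in the set is not: the limit of > 0.5 h in this assay, at which 1 of the 4 values shown sits.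

From the compounds shown here alone, it remains open whether a methoxy group or a fluorine atom on this same carbon would also leave the half-life within the scatter of these two values. Going by these compounds, it is also open whether a 1-hydroxycyclopentyl group would recover what 1-aminocyclopentyl appears to lose, and the numbers do not show which part of the molecule the microsomes attack.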